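Benzamido in place of chloro in a flat series

This account rests on a few compounds, and the source may have more. Where it says the series, first, only, none or still open, it means among the compounds named here.

In a functional assay on HepG2 cells (Homo sapiens) for cytotoxicity, read by MTT assay, with a stated time of 72 h (on this read-out higher numbers stand for weaker inhibition and lower numbers for stronger inhibition), compound 1 (`C#Cc1cccc(Nc2nc3cnc(Nc4ccc(N5CCN(C)CC5)cc4)nc3n2C2CCCC2)c1`) gives 4900 nM and compound 2 (`Cc1cccc(Nc2nc3cnc(Nc4ccc(N5CCN(C)CC5)cc4)nc3n2C2CCCC2)c1`) gives 4700 nM while compound 3 (`CN1CCN(c2ccc(Nc3ncc4nc(Nc5cccc(Cl)c5)n(C5CCCC5)c4n3)cc2)CC1`) gives 4800 nM so compound 3 stands level with the other two. Within the data shown here, three steps bear on the next change: a 1.0-fold lower number from compound 1 to compound 2 (0.02 log units; within the scatter) and a 1.0-fold lower number from compound 1 to compound 3 (0.01 log units; within the scatter) and a 1.0-fold higher number from compound 2 to compound 3 (0.01 log units; within the scatter) show no shift among methyl, chloro and ethynyl. Compound 4 (`CN1CCN(c2ccc(Nc3ncc4nc(Nc5cccc(NC(=O)c6ccccc6)c5)n(C5CCCC5)c4n3)cc2)CC1`) differs from compound 3 by benzamido in place of chloro on an aromatic carbon with benzamido in place of chloro on an aromatic carbon. Among the measured compounds shown here, no measured step tests a group of this size, so the range stays wide. The estimated step of a 1.2-fold lower number from compound 3 to compound 4 (0.08 log units; within the scatter) is expected to stay within the scatter in this assay without a firm direction. Compound 4 is estimated at 4000 nM with an expected range from 1500 nM to 10000 nM on this read-out.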

Compound 4, half-maximal inhibitory concentration: 2600 nM
Beside the measured number, compound 4's estimate is 1.5-fold (0.19 log units) above it; the measured number falls inside the stated range.
By their numbers in this assay, from the lowest: compounds 4, 2, 3 and 1 (each within the scatter of the next).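

In this assay this position accepts benzamido, with its nine heavy atoms and added six-membered aromatic ring, and every step stays within the scatter: a 1.8-fold lower number from compound 3 to compound 4 (0.27 log units; within the scatter) and a 1.8-fold lower number from compound 2 to compound 4 (0.26 log units; within the scatter) and a 1.9-fold lower number from compound 1 to compound 4 (0.28 log units; within the scatter). The flat picture therefore reaches beyond methyl, chloro and ethynyl to a much larger group carrying a hydrogen-bond donor and acceptor. No supporting data bear on the reason for this result.

As far as these compounds go, whether an amine, a carboxylic acid or a longer chain at this position would also leave the number flat stays open.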